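This account rests on a few compounds, and the source may have more. Where it says the series, first, only, none or still open, it means among the compounds named here.

Compound 2 `COc1ccc(CCCCCCCCOc2ccc(C[S+]([O-])c3ccccc3)nc2/C=C/C(=O)O)cc1` gives 37 nM in an assay for binding affinity to leukotriene B4 receptor 1 (Homo sapiens); on this read-out lower numbers stand for stronger inhibition and higher numbers for weaker inhibition. Among the three measured compounds it holds the second highest number: compound 3 `CCCCCCCCCCCCOc1ccc(C[S+]([O-])c2ccc(C(=O)O)cc2)nc1/C=C/C(=O)O` gives 252 nM, and compound 1 `CCCCCCCCC(O)/C=C/c1cccc(CC(O)c2cccc(C(=O)O)c2)n1` gives 1 nM, each of them beyond the scatter from compound 2. Compound 4 `COc1ccc(CCCCCCCCOc2ccc(CSc3cccc(OC)c3)nc2/C=C/C(=O)O)cc1` differs from compound 2 in one place: a group of 9 heavy atoms (7 carbon, 1 oxygen, 1 sulfur; one six-membered aromatic ring of carbon only) in place of a group of 8 heavy atoms (6 carbon, 1 oxygen, 1 sulfur; one six-membered aromatic ring of carbon only), on a saturated chain carbon bound to an aromatic carbon. Within the data shown here, no measured pair shows this particular change, so no step is known for it, and the expectation rests on the new group's size being close to that of the old one. The step expected in this assay is a 1.2-fold lower number from compound 2 to compound 4 (0.09 log units; within the scatter), small, and toward a lower number only if it reaches beyond the scatter at all. Compound 4 is therefore estimated at 30 nM, within a range from 8 nM to 120 nM.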

Compound 4, inhibition constant: 192 nM
Estimate against measurement, compound 4: 6.4-fold (0.81 log units) below; the whole stated range lies below it.
By their numbers in this assay, from the lowest: compound 1; then compound 2; then compounds 4 and 3 (each within the scatter of the next).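

Swapping the group in compound 2 for (3-methoxyphenyl)sulfanyl, on a saturated chain carbon bound to an aromatic carbon, gives a 5.2-fold higher number from compound 2 to compound 4 (0.72 log units; beyond the scatter) in this assay. This place therefore responds to the exchange of two groups of nearly the same size. The swap removes the oxygen on sulfur and adds a methoxy in one move, and nothing measured here explains the shift. Still open, as far as these compounds go, is how a plain phenylsulfanyl group would compare, which would help separate those two changes. An amine on that ring also remains an open case.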